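A few compounds are considered here, and "the series" means these few. Any claim that something is new, unique, unknown or untested is made for them only; others in the source may bear on it.

Measured in an ADME assay on HCT-116 cells (Homo sapiens) for cytotoxicity, read by CellTiter-Glo, with a stated time of 72 h; a higher number here means a weaker inhibitor, a lower number a stronger inhibitor:
Compound 1 `Cc1noc(C)c1S(=O)(=O)N1CCC(N2CCC(C)CC2)CC1`: > 10000 nM, a limit
Compound 2 `COc1ccccc1-c1cccc(S(=O)(=O)N2CCC(N3CCC(C)CC3)CC2)c1`: > 5000 nM, a limit

Compound 2 stands at > 5000 nM, which is a limit of the assay and not a number. Within the data shown here, the other entry is a limit too, so the series so far offers no numerical value to anchor on.

Compound 3 `CC1CCN(C2CCN(S(=O)(=O)c3cccc(-c4ccc(Cl)cc4)c3)CC2)CC1` differs from compound 2 by one change: 4-chlorophenyl in place of 2-methoxyphenyl on an aromatic carbon. The 4-chlorophenyl takes the place of the 2-methoxyphenyl, meta to a large group, and the rest of the structure is shared.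

Among the measured compounds shown here, no step between measured compounds is available to size this change. In this assay no shift beyond the usual scatter is expected, and the estimated step is a step that the limit leaves unreadable from compound 2 to compound 3. Another limit would be no surprise. Compound 3 is estimated at 6000 nM, with an expected range of 2000 nM to 15000 nM.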

Compound 3, half-maximal inhibitory concentration: > 5000 nM
Compound 3 ended at the assay's limit; the forecaster's own chance of this, stated with the estimate: 65%; the middle value is on the limit's open side.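

Among these compounds, compound 2 and compound 3 both stand at a limit of the assay and not at a number; no step between them can be read. The compounds shown leave open whether 4-chlorophenyl and 2-methoxyphenyl differ at all here, and at what concentration any of the three compounds reaches half-maximal inhibition.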